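From 3-fluorophenyl to 2-chlorophenyl on a sulfonyl sulfur

The compounds below may be only part of what the source reports. "The series", "measured", "known", "first", "only" and "open" are said of these compounds alone.

In an ADME assay on HEK293 cells (Homo sapiens) for cytotoxicity, read by resazurin assay, with a stated time of 48 h (on this read-out lower numbers stand for higher toxicity in this test and higher numbers for lower toxicity in this test), compound 1 (`O=S(=O)(Nc1ccc(-c2nc3ccccc3o2)cc1)c1cccc(F)c1`) gives > 100000 nM, and this is a limit of the assay, not a number. With the core of compound 1 kept and a different group on the sulfonyl sulfur, compound 2 (`O=S(=O)(Nc1ccc(-c2nc3ccccc3o2)cc1)c1ccc(Cl)c(C(F)(F)F)c1`) gives 69000 nM. Compound 3 (`Cc1ccc(S(=O)(=O)Nc2ccc3oc(-c4ccccc4)nc3c2)cc1`) gives 75000 nM in this assay.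

Going by the values given here, no two of these measured compounds differ in one place alone, so no measured step guides what comes next. Compound 4 (`O=S(=O)(Nc1ccc(-c2nc3ccccc3o2)cc1)c1ccccc1Cl`) carries 2-chlorophenyl in place of 3-fluorophenyl on a sulfonyl sulfur.

The expected change, an at least 1.1-fold lower number from compound 1 to compound 4 (0.07 log units; that floor lies within the scatter), is estimated to be no larger than the usual scatter, with any shift leaning toward lower numbers. This expectation rests on compound 2, which gives a measurable 69000 nM with the same core. The assay may again report only a limit. For compound 4 the estimated value is 85000 nM, with an expected range from 50000 nM to 120000 nM.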

Compound 4, half-maximal cytotoxic concentration: > 100000 nM
Compound 4: a limit, no number (the forecaster's own chance of this, stated with the estimate: 45%); at least 1.1-fold (0.07 log units) between middle value and limit.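

In this assay compound 4 gives > 100000 nM, which is a limit of the assay and not a number. No step can be read between compound 1 and compound 4, because both stand at the same limit: the limit of > 100000 nM in this assay, at which 2 of the 4 values shown sit.

The compounds shown leave open how far 2-chlorophenyl and 3-fluorophenyl on a sulfonyl sulfur differ in this assay.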